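From Compound 1 to Compound 4: An Expected Step

The compounds below may be only part of what the source reports. "The series", "measured", "known", "first", "only" and "open" are said of these compounds alone.

Compound 1 `COc1ccc(N2CCN(C(=S)SCc3ccc(C(=O)Nc4ccccc4N)cc3)CC2)cc1`: 28.1%
Compound 2 `CCN(Cc1ccncc1)C(=S)SCc1ccc(C(=O)Nc2ccccc2N)cc1`: 67.2%
Compound 3 `Nc1ccccc1NC(=O)c1ccc(CSC(=S)N(Cc2ccccc2)Cc2ccccc2)cc1`: 10.9%

In a functional assay on A-375 cells (Homo sapiens) for antiproliferative activity, read by CCK-8 assay, with a stated time of 72 h, tested at 2 uM (on this read-out higher numbers stand for a stronger effect at the one concentration tested and lower numbers for a weaker effect), compound 1 gives 28.1%, the second highest of the three numbers. Compound 3 lies nearest, with a number lower by more than the usual scatter, while compound 2 lies furthest and sits well above compound 1, again beyond the scatter.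

Compound 4 `Nc1ccccc1NC(=O)c1ccc(CSC(=S)N2CCN(c3ccncc3)CC2)cc1` has not yet been measured in this assay. It differs from compound 1 in one place: pyridin-4-yl in place of 4-methoxyphenyl on an amine nitrogen in a ring. For the measured compounds named here, no measured pair shares this exact change, so the size of the step is open. Because compound 2, which carries a pyridine on its nitrogen, gives 67.2%, the account leans toward a modest rise rather than a fall, though a step within the scatter would not surprise. The estimate for compound 4 is 38%, within a range from 20% to 60%. The expected step is a number 9.9 percentage points higher from compound 1 to compound 4 (within the scatter).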

Compound 4, a percentage reported as inhibition, at one concentration (the size of the read-out at that concentration, not a potency): 85.7%
Compound 4: the middle estimate sits 47.7 percentage points below what was measured; measured number above the stated range.
By their numbers in this assay, from the lowest: compound 3; then compound 1; then compound 2; then compound 4.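

Placing pyridin-4-yl in place of 4-methoxyphenyl on an amine nitrogen in a ring gives a number 57.6 percentage points higher from compound 1 to compound 4 (beyond the scatter) in this assay. For the compounds shown here, this is the first step that can be read at a single place, and it shows that this position is far from indifferent: exchanging one six-membered aromatic ring for another, with no net charge on either group, is enough to produce a large change. No measurement at hand says why the step is so large.

The compounds shown leave open how a plain phenyl, pyridin-3-yl or pyridin-2-yl would stand on this nitrogen, and so whether the step follows the ring nitrogen, its place in the ring or the loss of the methoxy group. They also leave open whether a step of this size holds on other cell lines.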